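The compounds below may be only part of what the source reports. "The series", "measured", "known", "first", "only" and "open" are said of these compounds alone.

In an assay on a protein complex for inhibition of CDK8/Cyclin C (Homo sapiens), with a stated time of 1 h (a lower number here means a stronger inhibitor, a higher number a weaker inhibitor), compound 2 `CNC(=O)CCc1ccncc1-c1ccc2ccccc2c1` gives 21.1 nM, and compound 1 `O=C(CCc1ccncc1-c1ccc2ccccc2c1)N1CCOCC1` gives 45.5 nM. The change between them, (morpholin-4-yl in place of methylamino on a carbonyl carbon), made a 2.2-fold higher number from compound 2 to compound 1 (0.33 log units; beyond the scatter). Compound 3 `CNC(=O)/C=C/c1ccncc1-c1ccc2cnn(C)c2c1` belongs to a different core, and the difference between the two cores is not broken down here; in this assay compound 3 gives 122 nM, the highest number of the three. Compound 4 `Cn1ncc2ccc(-c3cnccc3/C=C/C(=O)N3CCOCC3)cc21` has not been measured. It differs from compound 3 by morpholin-4-yl in place of methylamino on a carbonyl carbon. The place differs from the earlier pair: there the carbonyl carbon's other neighbour was a saturated chain carbon, here it is a double-bonded chain carbon, so it is the same kind of change, not the same. Resting on a 2.2-fold higher number from compound 2 to compound 1 (0.33 log units; beyond the scatter), a step of a 2.2-fold higher number from compound 3 to compound 4 (0.35 log units; beyond the scatter) is expected. Compound 4 is therefore estimated at 270 nM, between 130 nM and 560 nM.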

Compound 4, half-maximal inhibitory concentration: 853 nM
Compound 4: the middle estimate sits 3.2-fold (0.50 log units) below what was measured; measured number outside the range, above it.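

In this assay, morpholin-4-yl in place of methylamino on a carbonyl carbon again gives a higher number, with a 7.0-fold higher number from compound 3 to compound 4 (0.84 log units; beyond the scatter), so the direction of the change carried over to the second core but its size did not: the same change on two cores in this assay, a 2.2-fold higher number (0.33 log units; beyond the scatter) from compound 2 to compound 1 and a 7.0-fold higher number (0.84 log units; beyond the scatter) from compound 3 to compound 4, 3.2-fold (0.51 log units) apart, beyond the scatter of two such steps

The two cores differ in more than one place, and these two pairs do not show which difference goes with the larger step. Nor do they show what size the step would take on any further core.

From the compounds shown here alone, it remains open whether the saturated chain carbon or the rest of the core sets the size of the step. Also open, going by these compounds, is how piperidin-1-yl or dimethylamino in place of methylamino on the carbonyl carbon would behave on either core.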